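Anilino variation on the shared core: bromo to methoxy

A few compounds are considered here, and "the series" means these few. Any claim that something is new, unique, unknown or untested is made for them only; others in the source may bear on it.

Compound 1 `CC(C)CNc1nc(/C=C/c2ccccc2)nc2ccsc12` bears isobutyl on a nitrogen on an aromatic ring. In a functional assay on L02 cells (Homo sapiens) for inhibition, read by Griess assay, with stated times of 1 h and 24 h (on this read-out higher numbers stand for weaker inhibition and lower numbers for stronger inhibition), compound 1 gives only a limit, > 1000000 nM. Compound 2 `Brc1ccc(Nc2nc(/C=C/c3ccccc3)nc3ccsc23)cc1` bears 4-bromophenyl in place of isobutyl on a nitrogen on an aromatic ring. In this assay compound 2 likewise gives only a limit, > 1000000 nM. The step that the two limits leave unreadable from compound 1 to compound 2 is therefore unreadable, because the limit of > 1000000 nM in this assay, at which 2 of the 2 values shown sit, holds both values. Compound 3 `COc1ccc(Nc2nc(/C=C/c3ccccc3)nc3ccsc23)cc1` differs from compound 2 by methoxy in place of bromo on an aromatic carbon. Within the data shown here, no measured step bears on this change, and both anchors sit at the limit. Compound 3 is expected to stay at the limit, estimated at 2000000 nM within 200000 nM to 20000000 nM, an expected step that the limit leaves unreadable from compound 2 to compound 3.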

Compound 3, half-maximal inhibitory concentration: > 1000000 nM
Compound 3: only a limit was reported; the forecaster's own chance of this, stated with the estimate: 85%; the middle value lies beyond the limit too.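

No new step can be read from compound 1 or compound 2 to compound 3, because all three compounds stop at the same limit: the limit of > 1000000 nM in this assay, at which 3 of the 3 values shown sit.

The compounds shown leave open how the isobutyl, 4-bromophenyl and 4-methoxyphenyl groups rank in this assay.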